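Pyrazole ureas: trifluoromethyl to chloro swap

This account rests on a few compounds, and the source may have more. Where it says the series, first, only, none or still open, it means among the compounds named here.

Measured so far:
- compound 1, `O=C(Nc1cccc(-n2cc(-c3ccncc3)c(-c3cc(O)cc(Cl)c3)n2)c1)Nc1ccc(Cl)c(Cl)c1`, -12%
- compound 2, `COc1cc(Cl)cc(-c2nn(-c3cccc(NC(=O)Nc4ccc(Cl)c(C(F)(F)F)c4)c3)cc2-c2ccncc2)c1`, -16%

Both numbers come from a functional assay on IGROV-1 cells (Homo sapiens) for inhibition, read by sulforhodamine B assay, with a stated time of 48 h, tested at 100 uM; on this read-out higher numbers stand for a weaker effect at the one concentration tested and lower numbers for a stronger effect. Compound 2 stands as the lower of the two values, with compound 1 the nearest; the gap between them lies within the scatter, so the two compounds are indistinguishable on this read-out, and neither shows an effect at the concentration tested. Among the compounds with values here, no step between measured compounds is defined here, as the two differ in more than one place.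

Compound 3, `COc1cc(Cl)cc(-c2nn(-c3cccc(NC(=O)Nc4ccc(Cl)c(Cl)c4)c3)cc2-c2ccncc2)c1`, is yet to be measured. It departs from compound 2 by a single change, (chloro in place of trifluoromethyl on an aromatic carbon), on an aromatic carbon of a six-membered aromatic ring of carbon only, ortho to a chloro group; compound 3 thereby carries the 3,4-dichlorophenyl group already seen in compound 1.

Given that compound 1 with -12% and compound 2 with -16% both sit at no effect, the expected step of a number 2 percentage points higher from compound 2 to compound 3 (within the scatter) is none beyond the scatter. Compound 3 is therefore estimated at -14%, within -30% to 4%.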

Compound 3, a percentage reported as activity, at one concentration (the size of the read-out at that concentration, not a potency): 8%
Compound 3: middle estimate off by 22 percentage points, on the low side; measured number above the stated range.
By their numbers in this assay, from the lowest: compounds 2 and 1 (each within the scatter of the next); then compound 3.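

In this assay, the swap from 4-chloro-3-(trifluoromethyl)phenyl to 3,4-dichlorophenyl is not silent: chloro in place of trifluoromethyl on this aromatic carbon, ortho to a chloro group, gives a number 24 percentage points higher from compound 2 to compound 3 (beyond the scatter), a shift towards a weaker effect that the first two values could not reveal. With the 3,4-dichlorophenyl group held constant, methyl in place of hydrogen on the oxygen on the aromatic ring gives a number 20 percentage points higher from compound 1 to compound 3 (beyond the scatter), so this second position also registers on the read-out, and compound 3 stands as the weakest of the three, since both of its steps lie beyond the scatter. No measured property of these compounds is available to account for either step.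

The compounds shown leave open whether the read-out at this aromatic carbon follows a wider range of groups, such as a nitrile, a methyl or a bromo in place of the chloro. They also leave open how the aromatic oxygen position responds to an amine or a carboxylic acid in place of the methoxy group, with the 3,4-dichlorophenyl group kept.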